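Exchanging Nitro for Bromo on the Aromatic Ring

A few compounds are considered here, and "the series" means these few. Any claim that something is new, unique, unknown or untested is made for them only; others in the source may bear on it.

Compound 1 `CC1=C(/C=C/C(=O)/C=C/c2ccc(Br)cc2)C(C)(C)CCC1` gives 88800 nM in a functional assay on HeLa cells (Homo sapiens) for cytotoxicity, read by sulforhodamine B assay, with a stated time of 48 h; on this read-out lower numbers stand for stronger inhibition and higher numbers for weaker inhibition.
Compound 2 `CC1=C(/C=C/C(=O)/C=C/c2ccc(C)cc2)C(C)(C)CCC1` gives 20400 nM in this assay.
Compound 3 `CC1=C(/C=C/C(=O)/C=C/c2ccccc2[N+](=O)[O-])C(C)(C)CCC1` gives 36100 nM in this assay.

All three compounds share one core and differ only in the substituent on the aromatic ring. In this assay compound 3 stands second highest of the three numbers: compound 3 and compound 2 lie within the usual scatter of each other, whereas compound 1 lies beyond it, at a higher number.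

Compound 4 `CC1=C(/C=C/C(=O)/C=C/c2ccccc2Br)C(C)(C)CCC1` differs from compound 3 by bromo in place of nitro on an aromatic carbon. For the measured compounds named here, the only measured step, a 4.4-fold lower number from compound 1 to compound 2 (0.64 log units; beyond the scatter), involves a bromo group leaving rather than entering, and no measured pair removes a nitro group, so the bearing on this change is indirect. From that step, a bromo group is associated with a somewhat higher number, but the comparison is loose. The step expected in this assay is therefore small, leaning toward a higher number rather than a lower one, and quite possibly within the scatter: a 1.3-fold higher number from compound 3 to compound 4 (0.12 log units; within the scatter). Compound 4 is estimated at 48000 nM, with a range from 16000 nM to 140000 nM.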

Compound 4, half-maximal inhibitory concentration: 57900 nM
Estimate against measurement, compound 4: 1.2-fold (0.08 log units) below; the range from low to high includes it.
By their numbers in this assay, from the lowest: compounds 2, 3, 4 and 1 (each within the scatter of the next, the first and the last beyond it).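

In this assay, bromo in place of nitro on this aromatic carbon, ortho to a large group, gives a 1.6-fold higher number from compound 3 to compound 4 (0.21 log units; within the scatter), so the two groups cannot be told apart here. 2-Bromophenyl in place of 4-bromophenyl gives a 1.5-fold lower number from compound 1 to compound 4 (0.19 log units; within the scatter), so this shift of the bromo group also produces no readable difference. 2-Bromophenyl in place of 4-methylphenyl gives a 2.8-fold higher number from compound 2 to compound 4 (0.45 log units; beyond the scatter), a step beyond the scatter, but it changes both the group and its place, so neither change can be credited with it alone.

From the compounds shown here alone, whether an amine or a carboxylic acid on this aromatic carbon would separate from nitro and bromo remains open. Nothing measured here accounts for any of these steps.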